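The source may report more compounds than this note shows. Statements on the series, on what has been measured and on what is new or still open speak of the compounds shown alone.

Compound 3 `Cc1cccc2sc(NC(=O)CCN3CCN(CC4CCCO4)CC3)nc12` gives 109 nM in an assay on membranes from brain for displacement of a labelled ligand from Sigma non-opioid intracellular receptor 1 (Cavia porcellus), read by scintillation counting, with a stated time of 120 min (on this read-out higher numbers stand for weaker inhibition and lower numbers for stronger inhibition), the lowest number among the three measured compounds. Its nearest neighbour is compound 1 `CCN1CCN(CCC(=O)Nc2nc3c(C)cccc3s2)CC1`, which gives 543 nM, reached through the step of a 5.0-fold lower number from compound 1 to compound 3 (0.70 log units; beyond the scatter). Compound 2 `Cc1cccc2sc(NC(=O)CCN3CCN(CCN(C)C)CC3)nc12` gives 1000 nM, and the step of a 9.2-fold lower number from compound 2 to compound 3 (0.96 log units; beyond the scatter) is larger still, whereas the step of a 1.8-fold higher number from compound 1 to compound 2 (0.27 log units; within the scatter) is small. Compound 4 `Cc1ccccc1N1CCN(CCC(=O)Nc2nc3c(C)cccc3s2)CC1` carries 2-methylphenyl in place of (oxolan-2-yl)methyl on an amine nitrogen in a ring. Within the data shown here, both measured steps that bear on this change swapped the group on the same ring nitrogen and moved the number, yet neither placed an aromatic ring directly on that nitrogen, so there is no direct precedent. A step of comparable size in either direction seems possible, with a slight lean toward a lower number. Compound 4 is therefore expected to show 80 nM, within 15 nM to 400 nM, an estimated step of a 1.4-fold lower number from compound 3 to compound 4 (0.13 log units; within the scatter).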

Compound 4, inhibition constant: 1000 nM
Estimate against measurement, compound 4: 13-fold (1.10 log units) below; the whole stated range lies below it.
By their numbers in this assay, from the lowest: compound 3; then compounds 1, 2 and 4 (each within the scatter of the next).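

With 2-methylphenyl, the only aromatic ring placed directly on this ring nitrogen, the step of a 9.2-fold higher number from compound 3 to compound 4 (0.96 log units; beyond the scatter) shows that this group does not keep the gain seen with (oxolan-2-yl)methyl. The steps of a 1.8-fold higher number from compound 1 to compound 4 (0.27 log units; within the scatter) and no change at the digits printed from compound 2 to compound 4 (within the scatter) leave it level with ethyl and 2-(dimethylamino)ethyl, so of these four groups only (oxolan-2-yl)methyl stands apart. No measurement shown explains this. Still open, from the compounds shown here alone, is whether a benzyl group, which puts a carbon link between the ring and the nitrogen, would give a number like that of compound 3. The same question holds for cyclopentylmethyl, which has carbon in place of the ring oxygen.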